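A few compounds are considered here, and "the series" means these few. Any claim that something is new, unique, unknown or untested is made for them only; others in the source may bear on it.

Two compounds of the series have been run in a functional assay on the whole organism for inhibition, with Nicotiana tabacum as the target; on this read-out higher numbers stand for weaker inhibition and lower numbers for stronger inhibition. Compound 1 `Cc1nc(Nc2ccc(Br)cc2)c2cc[nH]c2n1` gives 170000000 nM. Compound 2 `Cc1nc(Nc2ccc(O)cc2)c2cc[nH]c2n1` gives 155000000 nM. For the measured compounds named here, the single step between them, a 1.1-fold lower number from compound 1 to compound 2 (0.04 log units; within the scatter), is a hydroxy in place of bromo on an aromatic carbon and stays inside the scatter. Compound 2 therefore holds the lowest of the two numbers, with compound 1 as its nearest neighbour and no separation beyond the scatter between the two.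

Compound 3 `Cc1nc(Nc2ccc(C#N)cc2)c2cc[nH]c2n1` is not yet measured. Its difference from compound 2 is cyano in place of hydroxy on an aromatic carbon, set on an aromatic carbon of a six-membered aromatic ring of carbon only, para to a large group. Going by the values given here, the only measured step bearing on this exchange is the one between compound 1 and compound 2, which lay within the scatter. For compound 3 in this assay no step beyond the scatter is therefore expected. The expected step from compound 2 is a 1.0-fold higher number from compound 2 to compound 3 (0.01 log units; within the scatter). Compound 3 is estimated at 160000000 nM, with a range of 70000000 nM to 360000000 nM.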

Compound 3, half-maximal inhibitory concentration: 501000000 nM
Compound 3: the middle estimate sits 3.1-fold (0.50 log units) below what was measured; measured number outside the range, above it.
By their numbers in this assay, from the lowest: compounds 2 and 1 (each within the scatter of the next); then compound 3.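

At this position, on an aromatic carbon para to a large group, the choice of group does register in this assay: cyano in place of hydroxy gives a 3.2-fold higher number from compound 2 to compound 3 (0.51 log units; beyond the scatter) and cyano in place of bromo gives a 2.9-fold higher number from compound 1 to compound 3 (0.47 log units; beyond the scatter) and both steps are modest. The exchange of bromo and hydroxy left compound 1 and compound 2 within the scatter of each other, so the position is not indifferent to every change, and of the three groups cyano alone stands apart. Nothing available on these compounds explains that separation.

Going by these compounds, whether the higher number is peculiar to cyano or recurs with other groups here, such as an amine, a carboxylic acid or a methoxy group, stays open. Also open, on these data alone, is whether any group at this position gives a number clearly lower than those of compound 1 and compound 2.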